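This account rests on a few compounds, and the source may have more. Where it says the series, first, only, none or still open, it means among the compounds named here.

Measured so far in a functional assay on SR cells (Homo sapiens) for inhibition, read by sulforhodamine B assay, with a stated time of 48 h; on this read-out higher numbers stand for lower toxicity in this test and lower numbers for higher toxicity in this test:
Compound 1 `O=C(Nc1cccc(-n2cc(-c3ccncc3)c(-c3ccc(Cl)c(O)c3)n2)c1)Nc1cccc(C(F)(F)F)c1`: > 32500 nM
Compound 2 `COc1cc(-c2nn(-c3cccc(NC(=O)c4cccc(C(F)(F)F)c4)c3)cc2-c2ccncc2)ccc1Cl`: > 50000 nM

Both results are limits of the assay and not numbers. Compound 1 gives > 32500 nM in this assay, which is a limit. Compound 2 gives > 50000 nM in this assay, which is also a limit. Compound 2 therefore sits at the limit (the limit of > 50000 nM in this assay, at which 1 of the 2 values shown sits); how far beyond it the true value lies is not known. With no change between two measured compounds to compare, the two results only show that neither compound reached the read-out within the tested range.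

Compound 3 `COc1cc(-c2nn(-c3cccc(NC(=O)c4ccc(Cl)c(C(F)(F)F)c4)c3)cc2-c2ccncc2)ccc1Cl` is the next compound and differs from compound 2 in one place: chloro in place of hydrogen on an aromatic carbon. A single chlorine enters on the aromatic carbon named, while the rest of the molecule is untouched. For the step from compound 2 to compound 3 in this assay no change beyond the usual scatter is expected; the estimated step is a step that the limit leaves unreadable from compound 2 to compound 3. Compound 3 is expected to give about 60000 nM, within 20000 nM to 150000 nM, most likely again reported as a limit.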

Compound 3, concentration lethal to 50% of the cells: > 32500 nM
Compound 3 ended at the assay's limit; the forecaster's own chance of this, stated with the estimate: 80%; the middle value does not contradict the limit.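

In this assay compound 3 gives > 32500 nM, which is a limit of the assay and not a number. For the compounds shown here, compound 2 also stands at a limit, so no step between compound 2 and compound 3 can be read. The compounds shown leave open whether chloro in place of hydrogen changes this read-out at all.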